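This account rests on a few compounds, and the source may have more. Where it says the series, first, only, none or still open, it means among the compounds named here.

Compound 1 `Fc1ccc2c(c1CNc1ncc(Oc3ccccc3)c3nncn13)CCO2` is tested in an ADME assay on microsomes from liver (Homo sapiens) for metabolic stability, read by LC-MS, using NADPH, with stated times of 5 min and 30 min, tested at 1 uM (a lower number here means slower removal, a higher number faster removal of the compound), where compound 1 gives 18 mL.min-1.g-1. Two companions share the fluoro-dihydrobenzofuranylmethylamino arm on a different core: compound 2 `Cc1nc(CO)ccc1-c1cnc(NCc2c(F)ccc3c2CCO3)c2cn[nH]c(=O)c12` gives 11 mL.min-1.g-1 and compound 3 `CN(C)C(=O)c1cc(-c2cnc(NCc3c(F)ccc4c3CCO4)c3cn[nH]c(=O)c23)n(C)n1` gives 21 mL.min-1.g-1, so the number for compound 1 lies between those of compound 2 and compound 3, and all three lie within the scatter of one another. For the measured compounds named here, the only step among the measured compounds, a 1.9-fold higher number from compound 2 to compound 3 (0.28 log units; within the scatter), exchanges one aromatic substituent for another and stays within the scatter. Compound 4 `O=C(Nc1cnc(NCc2c(F)ccc3c2CCO3)n2cnnc12)c1cccnc1` is not yet measured; it differs from compound 1 in that (((pyridin-3-yl)carbonyl)amino in place of phenoxy on an aromatic carbon). Going by the values given here, that step, too, swaps one substituent for another on the shared core, and nothing among the measured compounds suggests a move beyond the scatter. For compound 4 a value of 16 mL.min-1.g-1 is therefore expected, with a range of 7 mL.min-1.g-1 to 36 mL.min-1.g-1, which would mean an estimated step of a 1.1-fold lower number from compound 1 to compound 4 (0.05 log units; within the scatter).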

Compound 4, intrinsic clearance in microsomes: < 3 mL.min-1.g-1
Compound 4 was reported as a limit; the forecaster's own chance of this, stated with the estimate: 10%; middle value at least 5.3-fold (0.72 log units) away from the limit.
By their numbers in this assay, from the lowest: compounds 2, 1 and 3 (each within the scatter of the next). At a limit, below all of these: compound 4.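

At this aromatic carbon of the shared core, the exchange of phenoxy for ((pyridin-3-yl)carbonyl)amino gives an at least 6.0-fold lower number from compound 1 to compound 4 (0.77 log units; beyond the scatter) in this assay, the only step shown that lies beyond the scatter. Compound 4 gives < 3 mL.min-1.g-1, which is a limit and not a number. The size of the change is therefore known only as a bound: the limit of < 3 mL.min-1.g-1 in this assay, at which 1 of the 4 values shown sits.

The entering group brings the carbonyl-amino link and the ring nitrogen together, and the compounds shown leave open which of them goes with the lower number; benzoylamino, which keeps the link on a ring of carbon only, or pyridin-3-yloxy, which keeps the oxygen link, would separate the two. Also open, as far as these compounds go, is whether a small amide such as acetylamino, without the second ring, would give a step of this kind.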